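From 4-Chlorophenyl to 4-Hydroxy-3-methoxyphenyl at the Limit

The source may hold more compounds than are shown below. What is called first, only, known or untested is meant among the compounds shown, and "the series" means these compounds.

Compound 1 (`COc1ccc(-c2nc3cccc(-c4cc(OC)c(OC)c(OC)c4)c3o2)cc1`) gives > 25000 nM in a functional assay on MCF7 cells (Homo sapiens) for antiproliferative activity, read by MTT assay, with a stated time of 48 h (a higher number here means a weaker inhibitor, a lower number a stronger inhibitor), as a limit and not a number. Compound 2 (`COc1cc(-c2cccc3nc(-c4cccc(F)c4)oc23)cc(OC)c1OC`) gives > 25000 nM in this assay as a limit as well. Compound 3 (`COc1cc(-c2cccc3nc(-c4ccc(Cl)cc4)oc23)cc(OC)c1OC`) likewise gives only a limit of > 25000 nM in this assay and so has no number of its own. Compound 4 (`COc1cc(-c2nc3cccc(-c4cc(OC)c(OC)c(OC)c4)c3o2)ccc1O`) carries 4-hydroxy-3-methoxyphenyl in place of 4-chlorophenyl on an aromatic carbon of the shared core. The nearest measured changes on that aryl group are a step that the two limits leave unreadable from compound 1 to compound 3 and a step that the two limits leave unreadable from compound 2 to compound 3 and also a step that the two limits leave unreadable from compound 1 to compound 2 with none of them giving a size to carry over. All three compounds sit at one ceiling (the limit of > 25000 nM in this assay, at which 3 of the 3 values shown sit) and this favours no step beyond the scatter. The expected change is an at least 1.1-fold lower number from compound 3 to compound 4 (0.05 log units; that floor lies within the scatter) with only a slight lean toward stronger inhibition. Compound 4 is estimated at 22000 nM with an expected range from 5000 nM to 40000 nM and may well report only a limit.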

Compound 4, half-maximal inhibitory concentration: > 25000 nM
Compound 4: only a limit was reported (the forecaster's own chance of this, stated with the estimate: 65%); at least 1.1-fold (0.05 log units) between middle value and limit.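

In this assay compound 4 gives > 25000 nM, again a limit and not a number, so no step to it from compound 1, compound 2 or compound 3 can be read: the limit of > 25000 nM in this assay, at which 4 of the 4 values shown sit.

The compounds shown leave open how these aryl groups rank against one another, and which group, if any, would give a number rather than a limit in this assay.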